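Removing an Acetyl from a Butenolide Diterpenoid

This account rests on a few compounds, and the source may have more. Where it says the series, first, only, none or still open, it means among the compounds named here.

Measured compounds:
compound 1, `C=C(C)CC[C@]1(C)C2=CCC[C@](C)(C[C@@H](O)c3ccoc3)[C@H]2CC[C@H]1C`, 28700 nM
compound 2, `C=C(C)CCC[C@]1(C)C2=CCC[C@](C)(C[C@H](O)c3ccoc3)[C@H]2CC[C@H]1C`, 31200 nM
compound 3, `C=C(C)CC[C@]1(C)C2=CCC[C@](C)(C[C@@H](OC(C)=O)C3=CC(=O)OC3O)[C@H]2CC[C@H]1C`, 3300 nM

All three were tested in a functional assay on HL-60 cells (Homo sapiens) for antiproliferative activity, read by XTT assay, with a stated time of 72 h; on this read-out higher numbers stand for weaker inhibition and lower numbers for stronger inhibition. Compound 3 gives the lowest number of the three, and its gap to compound 1 and to compound 2 is beyond the scatter of this assay. The next compound, compound 4 with the structure `C=C(C)CC[C@]1(C)C2=CCC[C@](C)(C[C@@H](O)C3=CC(=O)OC3O)[C@H]2CC[C@H]1C`, has not yet been measured. It differs from compound 3 in one place: hydrogen in place of acetyl on an oxygen on a saturated carbon. Going by the values given here, no measured pair shows this exact change, so its size is uncertain. Compound 4 is expected to give a weaker inhibition, an estimated step of a 2.1-fold higher number from compound 3 to compound 4 (0.33 log units; beyond the scatter), since the hydroxy-bearing compound 1 gives 28700 nM. Compound 4 is therefore estimated at 7000 nM, within a range of 1800 nM to 28000 nM.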

Compound 4, half-maximal inhibitory concentration: 3300 nM
Beside the measured number, compound 4's estimate is 2.1-fold (0.33 log units) above it; the range from low to high includes it.
By their numbers in this assay, from the lowest: compounds 3 and 4 (each within the scatter of the next); then compounds 1 and 2 (each within the scatter of the next).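

In this assay, hydroxy in place of acetoxy on this saturated carbon gives no change at the digits printed from compound 3 to compound 4 (within the scatter) and so the acetyl is not required for this activity. With the hydroxy present in both, the non-aromatic five-membered ring group in place of the aromatic five-membered ring gives an 8.7-fold lower number from compound 1 to compound 4 (0.94 log units; beyond the scatter) and so the gap to compound 1 remains without the acetyl. Nothing measured here explains either step. Still open, on these data alone, is whether a longer acyl chain on this oxygen, or an amine in place of the hydroxy, would leave the activity unchanged.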